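The compounds below may be only part of what the source reports. "The series", "measured", "known", "first", "only" and "open" are said of these compounds alone.

Three close relatives of a diaryl urea were tested in a functional assay on HepG2 cells (Homo sapiens) for inhibition, read by MTT assay, with a stated time of 72 h; a lower number here means a stronger inhibitor, a higher number a weaker inhibitor. Compound 1 `Cc1ccccc1-n1cc(COc2cccc(NC(=O)Nc3ccc(Cl)c(C(F)(F)F)c3)c2)nn1` gives 3440 nM, compound 2 `Cc1cccc(-n2cc(COc3cccc(NC(=O)Nc4ccc(Cl)c(C(F)(F)F)c4)c3)nn2)c1` gives 7270 nM, and compound 3 `CC(C)c1cccc(-n2cc(COc3cccc(NC(=O)Nc4ccc(Cl)c(C(F)(F)F)c4)c3)nn2)c1` gives 3250 nM, the lowest number of the three, though compound 1 sits within the usual scatter of it; only compound 2 lies clearly apart. The moves seen so far were modest: a 2.1-fold higher number from compound 1 to compound 2 (0.32 log units; beyond the scatter), and a 2.2-fold lower number from compound 2 to compound 3 (0.35 log units; beyond the scatter), while a 1.1-fold lower number from compound 1 to compound 3 (0.02 log units; within the scatter). Compound 4 `O=C(Nc1cccc(OCc2cn(-c3ccccc3Br)nn2)c1)Nc1ccc(Cl)c(C(F)(F)F)c1` differs from compound 3 in one place: 2-bromophenyl in place of 3-isopropylphenyl on an aromatic nitrogen. The new group resembles the 2-methylphenyl of compound 1 in its size and position, and compound 1 in this assay is within scatter of compound 3. The expectation is therefore a 1.1-fold higher number from compound 3 to compound 4 (0.03 log units; within the scatter), with compound 4 estimated at 3500 nM, between 1500 nM and 8000 nM.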

Compound 4, half-maximal inhibitory concentration: 2810 nM
For compound 4 the middle estimate is 1.2-fold (0.10 log units) above the measured one; low and high end bracket the measured number.
By their numbers in this assay, from the lowest: compounds 4, 3 and 1 (each within the scatter of the next); then compound 2.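

In this assay, bromo in place of methyl on the same aromatic carbon stays within the scatter (a 1.2-fold lower number from compound 1 to compound 4 (0.09 log units; within the scatter)), and so does the exchange of 3-isopropylphenyl for 2-bromophenyl (a 1.2-fold lower number from compound 3 to compound 4 (0.06 log units; within the scatter)). This position on the aromatic nitrogen therefore accepts a halogen as well as the alkyl groups, and only compound 2 stands apart (a 2.6-fold lower number from compound 2 to compound 4 (0.41 log units; beyond the scatter)). No measurement at hand explains these steps. Still open, on these data alone, is whether 3-bromophenyl would follow compound 2, and whether a phenyl ring carrying an amine or a carboxylic acid would keep this level.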